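A few compounds are considered here, and "the series" means these few. Any claim that something is new, unique, unknown or untested is made for them only; others in the source may bear on it.

Compound 2 `CCOC(=O)c1cnc(-c2ccc(C(F)(F)F)cc2)nc1NN1C(=O)C=C(C)C1=O` gives the lower of the two numbers recorded so far in a functional assay on Jurkat cells for inhibition of nuclear factor NF-kappa-B complex (Homo sapiens); on this read-out higher numbers stand for weaker inhibition and lower numbers for stronger inhibition: compound 2 gives 400 nM, while its nearest neighbour, compound 1 `CCOC(=O)c1cnc(C(C)(C)C)nc1NN1C(=O)C=C(C)C1=O`, gives 1000 nM. For the measured compounds named here, the only step measured, a 2.5-fold lower number from compound 1 to compound 2 (0.40 log units; beyond the scatter), replaced tert-butyl with 4-(trifluoromethyl)phenyl. Compound 3 `CCOC(=O)c1cnc(CC2=CCCCC2)nc1NN1C(=O)C=C(C)C1=O` differs from compound 2 by (cyclohex-1-en-1-yl)methyl in place of 4-(trifluoromethyl)phenyl on an aromatic carbon, so the group on that aromatic carbon becomes again a non-aromatic one, with one six-membered non-aromatic ring of carbon only and one double bond outside aromatic rings. Going by the values given here, the single measured step bearing on this change was modest and ran toward the aromatic group; compound 3 moves away from it, so a modest rise in the number, back toward the level of compound 1, is expected, though the scatter could absorb much of it. The step from compound 2 to compound 3 is estimated as a 2.5-fold higher number from compound 2 to compound 3 (0.40 log units; beyond the scatter). Compound 3 is accordingly estimated at 1000 nM, within a range from 300 nM to 3500 nM.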

Compound 3, half-maximal inhibitory concentration: 2000 nM
The estimate for compound 3 lay 2.0-fold (0.30 log units) below the measured number; the range from low to high includes it.
By their numbers in this assay, from the lowest: compound 2; then compounds 1 and 3 (each within the scatter of the next).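

At this aromatic carbon, between two ring nitrogen atoms, this assay shows a 5.0-fold higher number from compound 2 to compound 3 (0.70 log units; beyond the scatter) when (cyclohex-1-en-1-yl)methyl replaces 4-(trifluoromethyl)phenyl. The comparison with tert-butyl gives a 2.0-fold higher number from compound 1 to compound 3 (0.30 log units; within the scatter) and so does not separate the two non-aromatic groups, although one contains a six-membered ring and the other does not; among these three compounds, only compound 2, with its aromatic ring, stands apart from the others. No evidence is available to explain this difference.

For the compounds shown here, with only one aromatic group in the set, it remains open whether the aromatic ring itself or its trifluoromethyl group goes with the lower number, a question a plain phenyl group would address. Going by these compounds, how an amine such as morpholine or a saturated cyclohexyl group would read at this carbon also remains open.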